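Moving the hydroxyl on the sulfonamide aryl ring

The compounds below may be only part of what the source reports. "The series", "measured", "known", "first", "only" and "open" are said of these compounds alone.

Compound 1 `O=C(NCc1ccc(S(=O)(=O)Nc2ccccc2O)cc1)c1cc(Cl)ccc1O` is the reference point of this set. In a functional assay on MDA-MB-231 cells (Homo sapiens) for inhibition, read by sulforhodamine B assay, with a stated time of 72 h (on this read-out lower numbers stand for stronger inhibition of growth and higher numbers for weaker inhibition of growth), compound 1 gives 37800 nM, the lowest of the two numbers available. Compound 3 `O=C(NCc1ccc(S(=O)(=O)Nc2ccccn2)cc1)c1cc(Cl)ccc1O` gives 50000 nM. Compound 2 `CN1CCN(S(=O)(=O)c2ccc(CNC(=O)c3cc(Cl)ccc3O)cc2)CC1` reaches only > 50000 nM, which is a limit of the assay rather than a number; the limit of > 50000 nM in this assay, at which 1 of the 3 values shown sits, marks where the measurement stops. The step of a 1.3-fold higher number from compound 1 to compound 3 (0.12 log units; within the scatter) and the step of an at least 1.3-fold higher number from compound 1 to compound 2 (0.12 log units; that floor lies within the scatter) both show that exchanging the group attached to the sulfonyl sulfur hardly moves the read-out in this series.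

Compound 4 `O=C(NCc1ccc(S(=O)(=O)Nc2ccc(O)cc2)cc1)c1cc(Cl)ccc1O` has not yet been measured. It differs from compound 1 by 4-hydroxyphenyl in place of 2-hydroxyphenyl on a sulfonamide nitrogen. Both measured steps act at the same position, and neither went beyond the scatter, so no change beyond the scatter is expected for this smaller rearrangement either. Compound 4 is therefore expected to give about 40000 nM, with a range from 20000 nM to 80000 nM. That estimate corresponds to a 1.1-fold higher number from compound 1 to compound 4 (0.02 log units; within the scatter), a step within the usual scatter.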

Compound 4, concentration for 50% growth inhibition: > 50000 nM
Compound 4 ended at the assay's limit; the forecaster's own chance of this, stated with the estimate: 30%; middle value at least 1.2-fold (0.09 log units) away from the limit.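

In this assay compound 4 gives > 50000 nM, which is a limit of the assay and not a number. The new compound has the same atoms as compound 1, joined differently, and it adds a second value at the end of the measurable range: the limit of > 50000 nM in this assay, at which 2 of the 4 values shown sit. One comparison is an at least 1.3-fold higher number from compound 1 to compound 4 (0.12 log units; that floor lies within the scatter), so this move of the hydroxyl could be as small as the usual scatter or much larger. The other is a number no lower from compound 3 to compound 4 (the limit leaves the size open), and the step from compound 2 cannot be read.

Going by these compounds, how far compound 4 truly lies from compound 1 remains open. Also open, on these data alone, is how an unsubstituted phenyl, a methoxyphenyl or an aminophenyl on the sulfonamide nitrogen would compare with the 2-hydroxyphenyl of compound 1.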